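Aryl exchange at the chiral chain carbon of the urea-type guanidine

This account rests on a few compounds, and the source may have more. Where it says the series, first, only, none or still open, it means among the compounds named here.

The series shares the core shown in compound 1, `Cc1nc(N)sc1CCCN/C(N)=N/C(=O)NCc1ccccc1`, and is read in a functional assay on HEK293T cells for agonist activity at histamine H2 receptor (Homo sapiens), read by beta-arrestin recruitment; on this read-out lower numbers stand for smaller maximal responses and higher numbers for larger maximal responses. Compound 1 gives 0.33. Compound 2, `Cc1nc(N)sc1CCCN/C(N)=N/C(=O)NC(C)c1ccco1`, gives 0.25. Within the data shown here, compound 2 and compound 1 lie within the scatter of each other, the sole measured step being a number 0.080 lower from compound 1 to compound 2 (within the scatter), so neither can be ranked against the other.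

Compound 3, `Cc1nc(N)sc1CCCN/C(N)=N/C(=O)NC(C)c1cccc(F)c1`, is the next step from compound 2: 3-fluorophenyl in place of furan-2-yl on a saturated chain carbon bound to an amide-type nitrogen and a saturated chain carbon. Among the measured compounds shown here, the one step already measured, 1-(furan-2-yl)ethyl for benzyl, was a number 0.080 lower from compound 1 to compound 2 (within the scatter), i.e. no movement beyond the scatter. Compound 3 carries a six-membered carbon-only ring as compound 1 does, plus a methyl on the chain carbon and a fluorine on the ring. On this basis, compound 3 is expected to sit close to compound 2, with an estimated step of a number 0.050 higher from compound 2 to compound 3 (within the scatter) in this assay. Compound 3 is therefore estimated at 0.3, with a range of 0.15 to 0.45.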

Compound 3, intrinsic activity: the largest response reached, as a fraction of the reference agonist's: 0.3
For compound 3 middle estimate and measured number coincide at the digits printed; the measured number falls inside the stated range.
By their numbers in this assay, from the lowest: compounds 2, 3 and 1 (each within the scatter of the next).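

At the saturated chain carbon bound to an amide-type nitrogen and a saturated chain carbon, 3-fluorophenyl in place of furan-2-yl reads in this assay as a number 0.050 higher from compound 2 to compound 3 (within the scatter). Among these compounds, the earlier step altered the chain carbon and the ring together, whereas this one alters the ring alone, so it is the first reading of aryl exchange at this position. A five-membered aromatic ring with one hetero atom and a fluorinated six-membered aromatic ring of carbon only cannot be told apart here, and no supporting measurement accompanies this result.

Open, as far as these compounds go, is how plain phenyl reads on this carbon, which would separate the fluorine from the ring exchange. Also open, from the compounds shown here alone, is how an ethyl or a longer chain in place of the methyl on this carbon reads in this assay.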